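A few compounds are considered here, and "the series" means these few. Any claim that something is new, unique, unknown or untested is made for them only; others in the source may bear on it.

- compound 1 `COc1ccc(C(=O)c2ccc(OC)c3c2OC(C)(C)C=C3)c(NC(=O)CBr)c1`: 980 nM
- compound 2 `COc1ccc(C(=O)c2ccc3c(c2)C=CC(C)(C)O3)c(NC(=O)CBr)c1`: 1870 nM

In a functional assay on A2780 cells (Homo sapiens) for antiproliferative activity, read by MTT assay, with a stated time of 48 h (on this read-out lower numbers stand for stronger inhibition and higher numbers for weaker inhibition), only these two numbers exist, and they lie within the usual scatter of each other, so compound 1 stands level with compound 2. Compound 3 `COc1ccc(C(=O)c2ccc(OC)c3c2OC(C)(C)C=C3)c(NC(=O)CN)c1` differs from compound 1 as follows: amino in place of bromo on a saturated chain carbon bound to a carbonyl carbon. That is, amino in place of bromo on a saturated chain carbon bound to a carbonyl carbon. Among the compounds with values here, no measured pair shows this change, so the expectation is loose. The expected change is a 2.0-fold higher number from compound 1 to compound 3 (0.31 log units; beyond the scatter), a small weakening near the edge of the scatter. Compound 3 is estimated at 2000 nM, with an expected range of 300 nM to 10000 nM.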

Compound 3, half-maximal inhibitory concentration: 380 nM
Beside the measured number, compound 3's estimate is 5.3-fold (0.72 log units) above it, and the stated range covers the measured number.
By their numbers in this assay, from the lowest: compound 3; then compounds 1 and 2 (each within the scatter of the next).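

In this assay, activity in this series does not depend on the bromo on the saturated chain carbon bound to a carbonyl carbon: amino in its place gives a 2.6-fold lower number from compound 1 to compound 3 (0.41 log units; beyond the scatter), a modest gain in potency. Within the data shown here, compounds 1 and 2 both carry bromo, so this is the first reading of any change at this position. Nothing at hand accounts for the step.

Open, on these data alone, is how a hydroxyl, a dimethylamino group or a longer chain would compare at this place. Also open, as far as these compounds go, is whether amino for bromo gives a similar step on the core of compound 2.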